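Removing One Methoxy Group: What Cytotoxicity Is Expected

The compounds below may be only part of what the source reports. "The series", "measured", "known", "first", "only" and "open" are said of these compounds alone.

Of the compounds shown here, two sharing one core have been measured so far. Compound 1 `COc1ccc(-c2cc(/C=C/C(=O)c3ccc(N)cc3)[nH]n2)cc1` gives 93% in a functional assay on SF-268 cells (Homo sapiens) for cytotoxicity, read by sulforhodamine B assay, with a stated time of 48 h, tested at 0.1 uM; a higher number here means a weaker effect of the compound at the concentration tested, a lower number a stronger effect. Compound 2 `COc1cc(-c2cc(/C=C/C(=O)c3ccc(N)cc3)[nH]n2)cc(OC)c1OC` gives 106% in this assay, the higher of the two numbers, and its gap to compound 1 lies beyond the usual scatter. Compound 3 `COc1ccc(-c2cc(/C=C/C(=O)c3ccc(N)cc3)[nH]n2)cc1OC` is not yet measured; it differs from compound 2 by hydrogen in place of methoxy on an aromatic carbon. Among the measured compounds shown here, no step between measured compounds shows the size of such a change, so only a small downward shift, probably within the scatter, is expected: a number 7 percentage points lower from compound 2 to compound 3 (within the scatter). Compound 3 is therefore estimated to give 99%, with a range from 86% to 112%.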

Compound 3, a percentage reported as activity, at one concentration (the size of the read-out at that concentration, not a potency): 101%
Estimate against measurement, compound 3: 2 percentage points below, and the stated range covers the measured number.
By their numbers in this assay, from the lowest: compounds 1, 3 and 2 (each within the scatter of the next, the first and the last beyond it).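

Taking away one methoxy group on the aromatic ring gives the first step below, and adding one gives the second, both in this assay (a number 5 percentage points lower from compound 2 to compound 3 (within the scatter); a number 8 percentage points higher from compound 1 to compound 3 (within the scatter)). So at this place, meta to a large group, swapping methoxy and hydrogen produces no change that can be told from the scatter. Nothing measured here explains this result. From the compounds shown here alone, whether an amine, a hydroxyl group or a fluorine atom at this place would move the number stays open. So does the effect of these compounds at other concentrations.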